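The compounds below may be only part of what the source reports. "The series", "measured", "known", "first", "only" and "open" are said of these compounds alone.

Compound 1 `COc1ncnc2c1ncn2C1O[C@H](CO)[C@H](O[C@@H]2OC(CO)[C@H](OP(=O)(O)O)C(OP(=O)(O)O)[C@@H]2O)[C@@H]1OP(=O)(O)O`: 0.57 nM
Compound 2 `O=P(O)(O)OC1[C@@H](OP(=O)(O)O)C(CO)O[C@@H](O[C@@H]2[C@H](OP(=O)(O)O)C(n3cnc4c(NC5CCCC5)ncnc43)O[C@@H]2CO)[C@H]1O`: 0.77 nM

Among the measured compounds shown here, these two values come from a functional assay (Hepatocyte) with Rattus norvegicus as the target (a lower number here means that less compound is needed, a higher number that more compound is needed for the effect), and are the only measurements available. For the measured compounds named here, compound 2 stands level with compound 1, the one compound it can be compared with. The step between them is a 1.4-fold higher number from compound 1 to compound 2 (0.13 log units; within the scatter) and it replaced methoxy on an aromatic carbon with cyclopentylamino.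

Compound 3 `CNc1ncnc2c1ncn2C1O[C@H](CO)[C@H](O[C@@H]2OC(CO)[C@H](OP(=O)(O)O)C(OP(=O)(O)O)[C@@H]2O)[C@@H]1OP(=O)(O)O` differs from compound 2 by one change: methyl in place of cyclopentyl on a nitrogen on an aromatic ring (methyl in place of cyclopentyl on a nitrogen on an aromatic ring, or cyclopentylamino to methylamino). Going by the values given here, the one measured step bears on this only indirectly, as it touched the same cyclopentylamino group but had methoxy, not methylamino, on its other side. Among the compounds with values here, no measured compound carries methylamino. Because of a 1.4-fold higher number from compound 1 to compound 2 (0.13 log units; within the scatter) in that single comparison, no step beyond the scatter is expected in this assay and no direction is favoured. The estimated change is a 1.1-fold lower number from compound 2 to compound 3 (0.04 log units; within the scatter) and it remains a small one. Compound 3 is expected at 0.7 nM with an estimated range from 0.25 nM to 2 nM in this measurement.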

Compound 3, half-maximal effective concentration: 0.8 nM
Compound 3: the middle estimate sits 1.1-fold (0.06 log units) below what was measured, and the stated range covers the measured number.
By their numbers in this assay, from the lowest: compounds 1, 2 and 3 (each within the scatter of the next).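

In this assay, exchanging the cyclopentyl on the nitrogen for methyl gives a 1.0-fold higher number from compound 2 to compound 3 (0.02 log units; within the scatter), so going from a five-membered ring of 5 heavy atoms to a single carbon with no ring leaves the number within the scatter. Among the compounds shown here, the comparison with the oxygen-linked group points the same way, with a 1.4-fold higher number from compound 1 to compound 3 (0.15 log units; within the scatter), and thus methoxy, cyclopentylamino and methylamino on this aromatic carbon all give numbers within the scatter of one another, with no compound here going against that. No measured evidence accounts for this lack of separation among the three compounds.

From the compounds shown here alone, it remains open whether the same holds for a bare amino group, a phenyl ring or a carboxylic acid at this aromatic carbon, any of which could show whether the position has a limit in this assay. The three compounds also share the rest of their structure, so they leave open whether the position would behave the same way if the phosphate groups of the shared core were replaced, for example by carboxylic acids.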